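Trading a Bromo Aryl Amide for a Dimethylamino Aryl Amide

This account rests on a few compounds, and the source may have more. Where it says the series, first, only, none or still open, it means among the compounds named here.

Of the compounds shown here, three sharing one core have been measured in an assay on Sf21 cells for inhibition of high affinity nerve growth factor receptor (Homo sapiens), read by HTRF, with a stated time of 30 min, in the presence of a further agent that is not named here; on this read-out higher numbers stand for weaker inhibition and lower numbers for stronger inhibition. Compound 1 `CC1(C)c2[nH]nc(NC(=O)c3ccccc3)c2CN1Cc1cc(F)cc(F)c1` carries a plain phenyl on the amide carbonyl, and in this assay compound 1 gives 190 nM. Compound 2 `CC1(C)c2[nH]nc(NC(=O)c3ccc(Br)cc3)c2CN1Cc1cc(F)cc(F)c1` adds a bromo to that ring, and compound 2 gives 710 nM. Compound 3 `CN1CCN(c2ccc(C(=O)Nc3n[nH]c4c3CN(Cc3cc(F)cc(F)c3)C4(C)C)cc2)CC1` carries a 4-methylpiperazin-1-yl instead, and compound 3 gives 17 nM. Compound 2 stands highest of the three. The bromo alone accounts for a 3.7-fold higher number from compound 1 to compound 2 (0.57 log units; beyond the scatter), whereas the 4-methylpiperazin-1-yl gives an 11-fold lower number from compound 1 to compound 3 (1.05 log units; beyond the scatter), and swapping bromo for that group gives a 42-fold lower number from compound 2 to compound 3 (1.62 log units; beyond the scatter).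

The step followed here leads to compound 4 `CN(C)c1cccc(C(=O)Nc2n[nH]c3c2CN(Cc2cc(F)cc(F)c2)C3(C)C)c1`, in which (3-(dimethylamino)phenyl in place of 4-bromophenyl on a carbonyl carbon). Within the data shown here, two measured steps bear on it. Removing the bromo while bringing in a nitrogen-containing group produced the large drop a 42-fold lower number from compound 2 to compound 3 (1.62 log units; beyond the scatter), and the bromo by itself raised the number, as a 3.7-fold higher number from compound 1 to compound 2 (0.57 log units; beyond the scatter) shows. Among the measured compounds shown here, compound 4 loses the bromo and gains a smaller group with one hydrogen-bond acceptor, so a lower number is expected, though a smaller move than the one to compound 3, with an expected step of an 8.9-fold lower number from compound 2 to compound 4 (0.95 log units; beyond the scatter). Compound 4 is estimated at 80 nM, within 25 nM to 250 nM.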

Compound 4, half-maximal inhibitory concentration: 270 nM
For compound 4 the middle estimate is 3.4-fold (0.53 log units) below the measured one; the whole stated range lies below it.
By their numbers in this assay, from the lowest: compound 3; then compounds 1 and 4 (each within the scatter of the next); then compound 2.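

In this assay, replacing the 4-bromophenyl with 3-(dimethylamino)phenyl gives a 2.6-fold lower number from compound 2 to compound 4 (0.42 log units; beyond the scatter), so this swap on the carbonyl carbon does help, but only modestly. Set against the plain phenyl, the dimethylamino group gives a 1.4-fold higher number from compound 1 to compound 4 (0.15 log units; within the scatter), so compound 4 matches compound 1 within the scatter, and the gain over compound 2 amounts to no more than what the unsubstituted ring already offers; a nitrogen-bearing group on this ring is therefore not enough in itself to reach the value of compound 3, which gives 17 nM, while compound 4 gives 270 nM. Nothing available here explains why the dimethylamino group fails to match the 4-methylpiperazin-1-yl group.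

Compound 3 and compound 4 differ both in the nitrogen-bearing group and in how it is attached to the ring, so the two influences cannot yet be separated. The 4-(dimethylamino)phenyl and 3-(4-methylpiperazin-1-yl)phenyl amides would pull them apart, and a morpholine in place of the piperazine would test whether the second ring nitrogen matters.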